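The source may hold more compounds than are shown below. What is called first, only, known or untested is meant among the compounds shown, and "the series" means these compounds.

Series notes. Compound 1 `COc1ccc(NC(=O)Nc2cccc(CNc3nccnc3Cl)c2)cc1` serves as the reference. In a functional assay on HepG2 cells (Homo sapiens) for antiproliferative activity, read by MTT assay, with a stated time of 48 h (a lower number here means a stronger inhibitor, a higher number a weaker inhibitor), compound 1 gives 12000 nM, the highest of the three numbers in hand. Compound 2 `O=C(Nc1cccc(CNc2nccnc2Cl)c1)Nc1ccc(Cl)cc1Cl` gives 7230 nM in this assay, and compound 3 `O=C(Nc1cccc(CNc2nccnc2Cl)c1)Nc1ccc(Cl)cc1Br` gives 6720 nM. The steps of a 1.7-fold lower number from compound 1 to compound 2 (0.22 log units; within the scatter) and a 1.8-fold lower number from compound 1 to compound 3 (0.25 log units; within the scatter) both stay within the scatter, as does a 1.1-fold lower number from compound 2 to compound 3 (0.03 log units; within the scatter), so the three measured compounds are not separated from one another on this read-out.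

Compound 4 `O=C(Nc1cccc(CNc2nccnc2Cl)c1)Nc1ccc(Cl)c(Cl)c1` has not yet been measured. It differs from compound 1 as follows: 3,4-dichlorophenyl in place of 4-methoxyphenyl on an amide-type nitrogen. The measured steps that bear on this are the two that also exchange the 4-methoxyphenyl for a chlorinated phenyl on the same amide-type nitrogen, a 1.7-fold lower number from compound 1 to compound 2 (0.22 log units; within the scatter) and a 1.8-fold lower number from compound 1 to compound 3 (0.25 log units; within the scatter), and neither reaches beyond the scatter. Within the data shown here, no measured compound carries a 3,4-dichlorophenyl, so the expectation rests on those two steps alone. For compound 4 the expected step is a 1.6-fold lower number from compound 1 to compound 4 (0.20 log units; within the scatter), a small lowering at most. Compound 4 is therefore estimated at 7500 nM in this assay, with a range from 3500 nM to 16000 nM.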

Compound 4, half-maximal inhibitory concentration: 6170 nM
Beside the measured number, compound 4's estimate is 1.2-fold (0.08 log units) above it; measured number inside the range.
By their numbers in this assay, from the lowest: compounds 4, 3, 2 and 1 (each within the scatter of the next).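

In this assay a third halogenated phenyl group on the amide-type nitrogen, 3,4-dichlorophenyl, also stays within the scatter of the 4-methoxyphenyl of the reference, with a 1.9-fold lower number from compound 1 to compound 4 (0.29 log units; within the scatter) on the record, so this exchange, like those in compound 2 and compound 3, does not separate a halogenated compound from compound 1. The halogenated compounds are not separated from one another either: a 1.1-fold lower number from compound 3 to compound 4 (0.04 log units; within the scatter) and a 1.2-fold lower number from compound 2 to compound 4 (0.07 log units; within the scatter) both lie within the scatter, so this read-out shows no preference among the three halogenated phenyl groups. No evidence at hand bears on these results.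

Every compound shown keeps a phenyl group on this nitrogen, so it remains open whether an aminoalkyl chain or a phenyl group carrying a carboxylic acid would give a step beyond the scatter. On these data alone, the shared core is the same throughout, so the effect of any change there also remains open.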